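A few compounds are considered here, and "the series" means these few. Any claim that something is new, unique, unknown or untested is made for them only; others in the source may bear on it.

Within the data shown here, in an ADME assay on microsomes from liver (Rattus norvegicus) for metabolic stability, with a stated time of 60 min, tested at 1 uM (on this read-out lower numbers stand for a less stable compound and higher numbers for a more stable compound), compound 1 `CNc1nc2c(-c3ccnc(OC)c3)cnn2cc1OC` gives 74% while compound 2 `COc1cc(-c2cnn3cc(OC)c(N(C)C)nc23)ccn1` gives 3% as the lower of the only two numbers at hand. Among the measured compounds shown here, the single measured step is a number 71 percentage points lower from compound 1 to compound 2 (beyond the scatter) and it consists of methyl in place of hydrogen on a nitrogen on an aromatic ring. Compound 3 `COc1cc(-c2cnn3cc(OC)c([C@H]4COC(C)(C)C4)nc23)ccn1` changes that same place: a group of 7 heavy atoms (6 carbon, 1 oxygen; one five-membered non-aromatic ring with 1 hetero atom) in place of a group of 3 heavy atoms (2 carbon, 1 nitrogen; no ring), on an aromatic carbon so the dimethylamino leaves, nitrogen included, and the new ring stands on the aromatic carbon ortho to a methoxy group. For the measured compounds named here, the earlier step bears on this one only in part, since no measured compound carries such a ring. A clear rise is expected, smaller than the earlier drop, though its size remains uncertain. The estimated step is a number 27 percentage points higher from compound 2 to compound 3 (beyond the scatter) in this assay as an expectation. For compound 3 the expected value is 30% with an estimated range from 8% to 65% in this read-out.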

Compound 3, percent of the compound remaining: 30%
For compound 3 middle estimate and measured number coincide at the digits printed; the range from low to high includes it.
By their numbers in this assay, from the lowest: compound 2; then compound 3; then compound 1.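

In this assay, the change from dimethylamino to the five-membered non-aromatic ring gives a number 27 percentage points higher from compound 2 to compound 3 (beyond the scatter), which shows that this aromatic carbon can carry a ring joined through carbon, with no nitrogen attached, and still give a higher number than dimethylamino does. Set against the smaller nitrogen group, however, the same ring gives a number 44 percentage points lower from compound 1 to compound 3 (beyond the scatter), so it makes up only part of the ground lost on adding the methyl on nitrogen. Nothing at hand accounts for either step.

The compounds shown leave open whether the rise belongs to the ring oxygen, the methyl groups on the ring, the defined stereocentre or simply the loss of the nitrogen. They also leave open how a primary amine or a morpholine ring would read at this place.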